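Thiosemicarbazone series on a shared core: note on compound 4

This account rests on a few compounds, and the source may have more. Where it says the series, first, only, none or still open, it means among the compounds named here.

Measured so far:
compound 1 `Cc1ccccc1NC1=C/C(=N/NC(N)=S)C(=O)N=C1Nc1ccccc1C` — 580 nM
compound 2 `CCOc1ccc(NC2=C/C(=N/NC(N)=S)C(=O)N=C2Nc2ccc(OCC)cc2)cc1` — 13700 nM
compound 3 `NC(=S)N/N=C1/C=C(Nc2ccc(Br)cc2)C(Nc2ccc(Br)cc2)=NC1=O` — 2580 nM

Three compounds share the core and differ only in the two anilino groups. In a functional assay on MCF7 cells (Homo sapiens) for antiproliferative activity, read by MTT assay, with a stated time of 72 h (a higher number here means a weaker inhibitor, a lower number a stronger inhibitor), compound 1 gives 580 nM, the lowest number of the three; compound 3 gives 2580 nM, and compound 2 gives 13700 nM, both beyond the scatter relative to compound 1.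

Compound 4 `Cc1ccccc1NC1=C/C(=N/N=C(\N)SCc2ccccc2)C(=O)N=C1Nc1ccccc1C` keeps the anilino groups of compound 1 and changes the substituent on the double-bonded nitrogen: a group of 11 heavy atoms (8 carbon, 2 nitrogen, 1 sulfur; one six-membered aromatic ring of carbon only) in place of a group of 4 heavy atoms (1 carbon, 2 nitrogen, 1 sulfur; no ring), on a double-bonded nitrogen. Among the compounds with values here, no measured pair shows this kind of change, so the direction is open. The change sits away from the part that varies among compounds 1 to 3, and a step in this assay of moderate size in either direction would be unsurprising; a modest weakening is the working assumption.

For compound 4 in this assay the estimate is 900 nM, with a range of 300 nM to 3000 nM. This estimate means an expected step of a 1.6-fold higher number from compound 1 to compound 4 (0.19 log units; within the scatter).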

Compound 4, half-maximal inhibitory concentration: 16300 nM
The estimate for compound 4 lay 18-fold (1.26 log units) below the measured number; measured number outside the range, above it.
By their numbers in this assay, from the lowest: compound 1; then compound 3; then compounds 2 and 4 (each within the scatter of the next).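

In this assay, the double-bonded nitrogen proves a sensitive place on the shared core: with the anilino groups of compound 1 kept, the group of 11 heavy atoms carrying one six-membered aromatic ring of carbon only, in place of the group of 4 heavy atoms with no ring, gives a 28-fold higher number from compound 1 to compound 4 (1.45 log units; beyond the scatter) in a single change. Within the data shown here, this is the first step that isolates one change, and it shows that this position alone can carry a large loss of antiproliferative activity. Nothing measured here bears on what lies behind the size of this step.

On these data alone, whether a smaller entering group, such as a methylthio group, would give a smaller step remains open. Also open, as far as these compounds go, is whether the step would hold with the 4-bromoanilino groups of compound 3.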